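From compound 1 to compound 4: loss of benzyl

The compounds below may be only part of what the source reports. "The series", "measured", "known", "first", "only" and "open" are said of these compounds alone.

Measured in an in vivo ADME assay on the whole organism (strain Sprague-Dawley) for metabolic stability, with Rattus norvegicus as the target, at a dose of 5 mg/kg by the intravenous route; a lower number here means that the compound disappears faster, a higher number that the compound lasts longer:
compound 1 `CC(C)CC[C@@]1(NCc2ccccc2)C(=O)C(C2=NS(=O)(=O)c3cc(NS(C)(=O)=O)ccc3N2)=C(O)c2ccccc21` gives 1.7 h
compound 2 `CC(C)(C)CCC1(NCc2ccc3ccccc3c2)C(=O)C(C2=NS(=O)(=O)c3cc(NS(C)(=O)=O)ccc3N2)=C(O)c2ccccc21` gives 2.2 h
compound 3 `COc1ccccc1CNC1(CCC(C)(C)C)C(=O)C(C2=NS(=O)(=O)c3cc(NS(C)(=O)=O)ccc3N2)=C(O)c2ccccc21` gives 3.2 h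

Compound 1 at 1.7 h lies within the scatter of both compound 2 and compound 3, so these three values form a single group with no order among them. Compound 4 `CC(C)CC[C@@]1(N)C(=O)C(C2=NS(=O)(=O)c3cc(NS(C)(=O)=O)ccc3N2)=C(O)c2ccccc21`, not yet measured, differs from compound 1 as follows: hydrogen in place of benzyl on an amine nitrogen. This is hydrogen in place of benzyl on an amine nitrogen, or benzylamino to amino.

Among the compounds with values here, no measured step removes this group. The closest evidence is a 1.5-fold higher number from compound 2 to compound 3 (0.16 log units; within the scatter), with 2-methoxyphenyl in place of naphthalen-2-yl on a saturated chain carbon bound to an amine nitrogen. That step exchanges one ring group for another, whereas the loss of benzyl leaves no ring group on the nitrogen, so it bears only weakly on the present change. On this thin basis, the expected step in this assay is a 1.1-fold lower number from compound 1 to compound 4 (0.05 log units; within the scatter), and no change beyond the scatter is expected, though the uncertainty stays wide. For compound 4 the estimated value is 1.5 h, with an expected range from 0.6 h to 4 h.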

Compound 4, half-life: 0.3 h
Estimate against measurement, compound 4: 5.0-fold (0.70 log units) above, outside the stated range (below it).
By their numbers in this assay, from the lowest: compound 4; then compounds 1, 2 and 3 (each within the scatter of the next).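

In this assay, within the data shown here, the amine nitrogen proves to be a place where the substituent matters: hydrogen in place of benzyl gives a 5.7-fold lower number from compound 1 to compound 4 (0.75 log units; beyond the scatter) and takes the series beyond the scatter for the first time. The earlier compounds shown here offered only an exchange of one ring group for another on a saturated chain carbon bound to an amine nitrogen (a 1.5-fold higher number from compound 2 to compound 3 (0.16 log units; within the scatter)), which left open whether a ring group on that nitrogen made any difference to half-life; the present pair shows that removing benzyl altogether does. Nothing at hand explains the shorter half-life of compound 4, and the finding rests on this single pair.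

Still open, from the compounds shown here alone, is whether the ring itself is needed or whether any substituent on the nitrogen would serve, a question that a methyl or an acetyl group there would address. Also open, going by these compounds, is how a longer chain between the nitrogen and the phenyl ring, such as phenethyl, would compare with benzyl on the same core.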